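The compounds below may be only part of what the source reports. "The series", "measured", "known", "first", "only" and "open" are said of these compounds alone.

In an ADME assay on BJ cells (Homo sapiens) for cytotoxicity, read by MTT assay, with a stated time of 72 h (a higher number here means that more compound is tolerated, a lower number that less compound is tolerated), compound 1 `OC[C@H]1O[C@@H](n2cc(Cl)c3c(-c4ccc(F)cc4)ncnc32)[C@H](O)[C@@H]1O` gives 49500 nM. Compound 3 `CCCCCCCCCCCCCCCCCCOP(=O)(O)OC[C@H]1O[C@@H](n2ccc3c(-c4ccoc4)ncnc32)[C@H](O)[C@@H]1O` gives 44200 nM, and these two numbers lie within the scatter of each other. Compound 2 `CCCCCCCCCCCCCCCCCCOP(=O)(O)OC[C@H]1O[C@@H](n2ccc3c(-c4ccccc4)ncnc32)[C@H](O)[C@@H]1O` is reported as a limit of the assay, > 50000 nM.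

Compound 4 `CCCCCCCCCCCCCCCCCCOP(=O)(O)OC[C@H]1O[C@@H](n2ccc3c(-c4ccsc4)ncnc32)[C@H](O)[C@@H]1O` differs from compound 3 by a single exchange, thiophen-3-yl in place of furan-3-yl on an aromatic carbon. Going by the values given here, one measured step bears on this exchange, since furan-3-yl replaced phenyl on the same aromatic carbon, giving an at least 1.1-fold lower number from compound 2 to compound 3 (0.05 log units; that floor lies within the scatter). That step starts from a limit, and its floor does not rise beyond the scatter. It therefore offers no sign that a swap of group at this carbon moves the number much, and no step beyond the scatter is expected in this assay, in either direction. For compound 4 the expected value is 42000 nM, with an estimated range from 20000 nM to 50000 nM. This estimate means an expected 1.1-fold lower number from compound 3 to compound 4 (0.02 log units; within the scatter).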

Compound 4, half-maximal cytotoxic concentration: > 50000 nM
Compound 4: only a limit was reported; the forecaster's own chance of this, stated with the estimate: 30%; middle value at least 1.1-fold (0.07 log units) away from the limit.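

In this assay, thiophen-3-yl in place of furan-3-yl on this aromatic carbon gives an at least 1.1-fold higher number from compound 3 to compound 4 (0.05 log units; that floor lies within the scatter), so this exchange, like the earlier one of phenyl for furan-3-yl, shows no step beyond the scatter. The step between compound 2 and compound 4 cannot be read, since both values are limits. Compound 4 now stands with compound 2 at the same limit: the limit of > 50000 nM in this assay, at which 2 of the 4 values shown sit.

As far as these compounds go, how far the true numbers of compound 2 and compound 4 lie past that limit stays open, and with it any difference between phenyl and thiophen-3-yl at this position. The compounds shown also leave open whether an amine or a carboxylic acid on this aromatic carbon would give a number clearly apart from these.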